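The compounds below may be only part of what the source reports. "The series", "measured", "known", "first", "only" and "open" are said of these compounds alone.

Measured in a functional assay, with a stated time of 20 min, tested at 10 uM; on this read-out higher numbers stand for a stronger effect at the one concentration tested and lower numbers for a weaker effect:

compound 1 `COc1cc(/C=C/C(=O)C2=C(/C=C/c3ccc(O)c(OC)c3)NC(=O)NC2c2ccccc2)ccc1O`: 20%
compound 2 `COc1cc(/C=C/C(=O)C2=C(/C=C/c3ccc(O)c(OC)c3)NC(=O)NC2c2ccc(C)cc2)ccc1O`: 23.9%
compound 3 `COc1cc(/C=C/C(=O)C2=C(/C=C/c3ccc(O)c(OC)c3)NC(=S)NC2c2ccccc2)ccc1O`: 22%

Compound 1 and compound 2 differ by methyl in place of hydrogen on an aromatic carbon, and the step of a number 3.9 percentage points higher from compound 1 to compound 2 (within the scatter) stays within the scatter, so the two values do not separate. Compound 3 differs from compound 1 in more than one place; the difference between the two cores is not broken down here, and its value sits within the scatter of both compound 1 and compound 2. Compound 4 `COc1cc(/C=C/C(=O)C2=C(/C=C/c3ccc(O)c(OC)c3)NC(=S)NC2c2ccc(C)cc2)ccc1O` is not yet measured in this assay ; it differs from compound 3 by methyl in place of hydrogen on an aromatic carbon, the same change already seen from compound 1 to compound 2. Because a number 3.9 percentage points higher from compound 1 to compound 2 (within the scatter) was small, the expected step is also small: a number 3 percentage points higher from compound 3 to compound 4 (within the scatter). Compound 4 is estimated at 25%, with a range from 12% to 38%.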

Compound 4, a percentage reported as activity, at one concentration (the size of the read-out at that concentration, not a potency): 19.9%
Compound 4: middle estimate off by 5.1 percentage points, on the high side; measured number inside the range.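

In this assay, methyl in place of hydrogen on the aromatic carbon gives a number 2.1 percentage points lower from compound 3 to compound 4 (within the scatter). Set beside the earlier step, the change reads alike on the two cores: the same change on two cores in this assay, a number 3.9 percentage points higher (within the scatter) from compound 1 to compound 2 and a number 2.1 percentage points lower (within the scatter) from compound 3 to compound 4, 6 percentage points apart, within the scatter of two such steps. The methyl therefore carries over between these two cores without a separable effect, but two steps this small do not show that it has any real effect, and they say nothing about the same change on other cores.

Still open, from the compounds shown here alone, is whether another group on the same aromatic carbon, such as an amine, a carboxylic acid or a longer chain, would move the read-out beyond the scatter. Going by these compounds, with methyl as the only substituent compared here, the reach of this position remains untested by these compounds.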